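Swapping the carboxy group of compound 3 for a longer chain

A few compounds are considered here, and "the series" means these few. Any claim that something is new, unique, unknown or untested is made for them only; others in the source may bear on it.

Compound 1 `CCOc1ccccc1-c1ncc(C(=O)O)c(=O)[nH]1`: 0.5 mg/kg
Compound 2 `O=C(O)c1cnc(-c2cccc(C(F)(F)F)c2)[nH]c1=O`: 33 mg/kg
Compound 3 `CCOc1ccc(C(=O)O)cc1-c1ncc(C(=O)O)c(=O)[nH]1`: 25 mg/kg

In a functional assay on the whole organism (strain Sprague-Dawley) for inhibition, with Rattus norvegicus as the target, with a stated time of 10 min (on this read-out lower numbers stand for an effect already at smaller amounts and higher numbers for an effect only at larger amounts of compound), compound 3 gives 25 mg/kg. This lies within the usual scatter of compound 2 at 33 mg/kg, while compound 1 stands well apart at 0.5 mg/kg.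

Compound 4 `CCOC(=O)C(=O)Nc1ccc(OCC)c(-c2ncc(C(=O)O)c(=O)[nH]2)c1` has not yet been measured. It carries ((ethoxycarbonyl)carbonyl)amino in place of carboxy on an aromatic carbon. Going by the values given here, only one measured step bears on this change: a 50-fold higher number from compound 1 to compound 3 (1.70 log units; beyond the scatter). That large step came with carboxy in place of hydrogen on an aromatic carbon. Compound 4 gives up that carboxy, so some of the step may be undone. However, the entering group is not hydrogen, and no measured compound carries it. A moderate move towards a lower number in this assay is therefore expected, short of the full way back. The expected change is a 4.2-fold lower number from compound 3 to compound 4 (0.62 log units; beyond the scatter). For compound 4 the estimated value is 6 mg/kg, with an expected range from 1 mg/kg to 30 mg/kg.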

Compound 4, dose for 50% inhibition: 25 mg/kg
Compound 4: the middle estimate sits 4.2-fold (0.62 log units) below what was measured, within the range that was stated.
By their numbers in this assay, from the lowest: compound 1; then compounds 3, 4 and 2 (each within the scatter of the next).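

In this assay, replacing the carboxy group of compound 3 with the much larger ((ethoxycarbonyl)carbonyl)amino group gives no change at the digits printed from compound 3 to compound 4 (within the scatter), so this exchange leaves the dose needed unmoved. Measured against hydrogen at the same place, the new group gives a 50-fold higher number from compound 1 to compound 4 (1.70 log units; beyond the scatter), the same size as a 50-fold higher number from compound 1 to compound 3 (1.70 log units; beyond the scatter) for carboxy. At this aromatic carbon, para to an ethoxy group, the high number therefore does not belong to carboxy alone: two different groups, both with one hydrogen-bond donor, go with it, while hydrogen in compound 1 does not.

Nothing available here explains why these two groups match. Going by these compounds, it remains open whether a plain amine or a methoxy group on this carbon would stay close to compound 3 or move back towards compound 1.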